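Efficacy at the bile acid receptor: a linker change

The source may report more compounds than this note shows. Statements on the series, on what has been measured and on what is new or still open speak of the compounds shown alone.

Measured compounds:
Compound 1, `CN(Cc1cccc(C(=O)O)c1)c1ccc(OCc2c(-c3c(Cl)cccc3Cl)noc2C2CC2)nc1C(F)(F)F`: 102%
Compound 2, `O=C(O)c1ccccc1OCc1ccc(OCc2c(-c3c(Cl)cccc3Cl)noc2C2CC2)nc1C(F)(F)F`: 91%

In an assay on isolated protein for agonist activity at Bile acid receptor (Homo sapiens), read by FRET (a higher number here means a larger maximal response, a lower number a smaller maximal response), compound 1 gives 102%, and compound 2 gives 91%, the lowest of the two numbers. Within the data shown here, the one step known is a number 11 percentage points lower from compound 1 to compound 2 (beyond the scatter), a modest drop.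

Compound 3, `CC(Oc1ccc(C(=O)O)cc1)c1ccc(OCc2c(-c3c(Cl)cccc3Cl)noc2C2CC2)nc1C(F)(F)F`, has not yet been measured in this assay. It differs from compound 2 in one place: 1-(4-carboxyphenoxy)ethyl in place of (2-carboxyphenoxy)methyl on an aromatic carbon. Both the carboxyphenoxy part and the connecting group are altered at once.

Among the measured compounds shown here, no measured step matches this change. For the measured compounds named here, the only step available, from compound 1 to compound 2, was modest, so a similarly sized step, in either direction, seems the most reasonable expectation here; a very large shift would be unsupported. Compound 3 is therefore expected to give 95%, within a range from 75% to 112%, which means an estimated step of a number 4 percentage points higher from compound 2 to compound 3 (within the scatter).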

Compound 3, largest response reached (reported as efficacy), in percent of the reference or control that the assay uses: 89%
For compound 3 the middle estimate is 6 percentage points above the measured one, within the range that was stated.
By their numbers in this assay, from the lowest: compounds 3 and 2 (each within the scatter of the next); then compound 1.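

In this assay, putting 1-(4-carboxyphenoxy)ethyl in place of (2-carboxyphenoxy)methyl gives a number 2 percentage points lower from compound 2 to compound 3 (within the scatter), so this aromatic carbon tolerates that swap, which involves both the point of attachment of the carboxyl group and one extra heavy atom. The other comparison gives a number 13 percentage points lower from compound 1 to compound 3 (beyond the scatter), so both carboxyphenoxy compounds, not just compound 2, now sit beyond the scatter from the (3-carboxybenzyl)(methyl)amino compound, though only modestly. No evidence is available to explain these results.

The two parts of the swap cannot be separated here, since a (4-carboxyphenoxy)methyl group or a 1-(2-carboxyphenoxy)ethyl group does not appear among these compounds. From the compounds shown here alone, it also remains open how the maximal response would respond at this position if a tetrazole or a primary amide stood in place of the carboxylic acid.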